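The compounds below may be only part of what the source reports. "The series", "measured", "known", "first", "only" and "open" are said of these compounds alone.

Compound 2 `Brc1ccc(OCC2=NCCO2)cc1` gives 10% in a toxicity assay on the whole organism with Rattus norvegicus as the target, at a dose of 200 mg/kg by the oral route (a higher number here means a stronger effect of the compound at the dose given, a lower number a weaker effect), level with compound 1 `COc1ccc(OCC2=NCCO2)cc1`, which gives 10% in this assay, and together these are the lowest of the three numbers. Among the measured compounds shown here, the one measured step, no change at the digits printed from compound 1 to compound 2 (within the scatter), shows that swapping one group for another at this place of the shared core left the number where it was. For the measured compounds named here, compound 3 `O=[N+]([O-])c1ccccc1OCC1=NCCO1`, which carries a nitro group at another carbon of the same ring, gives 25% in this assay, a higher number than compound 2, beyond the scatter; no step between these two is computed here.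

Compound 4 `O=[N+]([O-])c1ccc(OCC2=NCCO2)cc1` differs from compound 2 by nitro in place of bromo on an aromatic carbon. Going by the values given here, the only measured step at this place was flat, while the nitro group elsewhere in compound 3 came with a higher number, so a small rise is a fair expectation, but its size is uncertain. For compound 4 the expected step is a number 5 percentage points higher from compound 2 to compound 4 (within the scatter). Compound 4 is thus estimated at 15%, within 5% to 30%.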

Compound 4, a percentage reported as activity, at one dose (the size of the read-out at that dose, not a potency): 15%
Compound 4: the middle estimate sits on the measured number at the digits printed; the range from low to high includes it.
By their numbers in this assay, from the lowest: compounds 1, 2, 4 and 3 (each within the scatter of the next, the first and the last beyond it).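

In this assay the aromatic carbon para to a group of 7 heavy atoms now has three groups to compare, and nitro in place of bromo gives a number 5 percentage points higher from compound 2 to compound 4 (within the scatter) while nitro in place of methoxy gives a number 5 percentage points higher from compound 1 to compound 4 (within the scatter). With the earlier swap of bromo for methoxy also flat, methoxy, bromo and nitro cannot be told apart at this place at this single dose, even though nitro brings 3 heavy atoms and 2 hydrogen-bond acceptors where bromo has 1 heavy atom and no acceptors. No evidence is available that would explain this result. On these data alone, it remains open whether an amine or a carboxylic acid at this place would shift the number beyond the scatter. Also open, as far as these compounds go, is whether these three groups would stay level at other doses.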